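The source may hold more compounds than are shown below. What is called first, only, known or untested is meant among the compounds shown, and "the series" means these compounds.

Three compounds of this series carry numbers in a functional assay on the whole organism for inhibition, with Rattus norvegicus as the target, read by paw edema, with stated times of 30 min and 2 h, at a dose of 0.28 mmol/kg by the oral route; a higher number here means more inhibition at the dose given (going by the name of the read-out), a lower number less inhibition. Compound 1 `COc1ccc(-n2nc(C(N)=O)nc2-c2cc(OC)c(OC)c(OC)c2)cc1` gives 59% there. Compound 2 `CCNC(=O)c1nc(-c2cc(OC)c(OC)c(OC)c2)n(-c2ccc(OC)cc2)n1` carries ethyl in place of hydrogen on an amide-type nitrogen and gives 68%; the step is a number 9 percentage points higher from compound 1 to compound 2 (within the scatter). Compound 3 `COc1ccc(-n2nc(C(=O)Nc3cccc(F)c3)nc2-c2cc(OC)c(OC)c(OC)c2)cc1` carries 3-fluorophenyl on that nitrogen and gives 67%. Against its two neighbours compound 3 stands a number 1 percentage points lower from compound 2 to compound 3 (within the scatter) and a number 8 percentage points higher from compound 1 to compound 3 (within the scatter), so the three numbers in this assay cannot be told apart.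

Compound 4 `COc1ccc(-n2nc(C(=O)Nc3ccccc3)nc2-c2cc(OC)c(OC)c(OC)c2)cc1` is the next member. From compound 3 the change is hydrogen in place of fluoro on an aromatic carbon. Going by the values given here, none of the measured steps touches this ring: all three concern the group on the amide-type nitrogen, and none of them exceeds the scatter. Among the compounds with values here, the fluoro to hydrogen change therefore has no direct precedent, and with every step so far flat, the expected step in this assay is a number 1 percentage points lower from compound 3 to compound 4 (within the scatter), that is, none beyond the scatter. Compound 4 is accordingly estimated at 66%, with a range from 55% to 77%.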

Compound 4, a percentage reported as inhibition, in the whole organism at one dose (the size of the read-out at that dose, not a potency): 51%
The estimate for compound 4 lay 15 percentage points above the measured number, outside the stated range (below it).
By their numbers in this assay, from the lowest: compounds 4, 1, 3 and 2 (each within the scatter of the next, the first and the last beyond it).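

In this assay, going by these compounds alone, the fluoro on the aromatic carbon is the first place where a single change gives a step beyond the scatter: a number 16 percentage points lower from compound 3 to compound 4 (beyond the scatter), so this ring position is not silent, although all the earlier steps at the amide-type nitrogen were flat. Phenyl on that nitrogen also separates from ethyl, with a number 17 percentage points lower from compound 2 to compound 4 (beyond the scatter), whereas against hydrogen on the same nitrogen it shows a number 8 percentage points lower from compound 1 to compound 4 (within the scatter), so phenyl and hydrogen cannot be told apart. Nothing available bears on why the fluoro matters here.

As far as these compounds go, whether the step belongs to fluoro itself or to any group at this place remains open, as chloro, methyl or methoxy on the phenyl ring would test that. Also open, from the compounds shown here alone, is how a longer chain than ethyl on the amide-type nitrogen would read.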